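The compounds below may be only part of what the source reports. "The series", "measured", "known", "first", "only" and "open" are said of these compounds alone.

Compound 1 `Cc1cccc2cc(/C=C/C(=O)c3ccc(I)s3)c(Cl)nc12`: 284 nM
Compound 2 `Cc1ccc2cc(/C=C/C(=O)c3ccc(I)s3)c(Cl)nc2c1`: 135 nM
Compound 3 `Cc1ccc2nc(Cl)c(/C=C/C(=O)c3sccc3Cl)cc2c1`: 37.5 nM

All three compounds were tested in a functional assay on HUVEC cells (Homo sapiens), read by BrdU incorporation, with a stated time of 72 h; a lower number here means a stronger inhibitor, a higher number a weaker inhibitor. Compound 3 has the lowest number of the three, and its gaps to both others lie beyond the scatter, so it is the strongest inhibitor of this small set. Compound 4 `Cc1ccc2nc(Cl)c(/C=C/C(=O)c3ccc(I)s3)cc2c1` has 5-iodothiophen-2-yl in place of 3-chlorothiophen-2-yl on a carbonyl carbon. Within the data shown here, no measured pair shows this change alone. Compound 1 at 284 nM and compound 2 at 135 nM carry the incoming group, although their cores differ from that of compound 3. A weaker inhibitor is therefore expected, with an estimated step beyond the scatter of a 3.2-fold higher number from compound 3 to compound 4 (0.51 log units; beyond the scatter). The expected value for compound 4 is 120 nM, within an estimated range of 45 nM to 300 nM.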

Compound 4, half-maximal inhibitory concentration: 129 nM
Estimate against measurement, compound 4: 1.1-fold (0.03 log units) below; measured number inside the range.
By their numbers in this assay, from the lowest: compound 3; then compounds 4 and 2 (each within the scatter of the next); then compound 1.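

Across the same core, 5-iodothiophen-2-yl in place of 3-chlorothiophen-2-yl on a carbonyl carbon gives a 3.4-fold higher number from compound 3 to compound 4 (0.54 log units; beyond the scatter) in this assay and is the first direct reading of this change. It shows that the thiophene group at this place affects inhibition, with compound 3 the stronger of this pair. No measured evidence here bears on the reason for the step.

The change swaps both the halogen and its place on the thiophene, so the two effects remain unseparated. A 5-chlorothiophen-2-yl or 3-iodothiophen-2-yl group would tell them apart.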